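The compounds below may be only part of what the source reports. "The series", "measured", "known", "first", "only" and "open" are said of these compounds alone.

Measured compounds:
compound 1, `CS(=O)(=O)c1ccc(Nc2nccc(Nc3nc4ccc(F)cc4s3)n2)cc1`, gives > 60000 nM in a functional assay on MCF7 cells (Homo sapiens) for antiproliferative activity, read by MTT assay, with a stated time of 48 h; a lower number here means a stronger inhibitor, a higher number a weaker inhibitor
compound 2, `Cc1cnc(Nc2ccc(S(C)(=O)=O)cc2)nc1Nc1nc2ccc(F)cc2s1`, gives 3260 nM

The value for compound 1 is a limit of the assay, not a number. Compound 2 therefore gives the only number shown, and the step of an at least 18-fold lower number from compound 1 to compound 2 (1.26 log units; beyond the scatter) lies beyond the scatter. Compound 3, `Cc1cnc(Nc2ccc(S(N)(=O)=O)cc2)nc1Nc1nc2ccc(F)cc2s1`, differs from compound 2 by amino in place of methyl on a sulfonyl sulfur. Within the data shown here, the single measured step concerns a methyl on an aromatic carbon, a different place, so no measured step bears directly on this change. The expected step of a 1.3-fold lower number from compound 2 to compound 3 (0.12 log units; within the scatter) is small, within the scatter. Compound 3 is estimated at 2500 nM, between 800 nM and 8000 nM.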

Compound 3, half-maximal inhibitory concentration: > 50000 nM
Compound 3: a limit, no number (the forecaster's own chance of this, stated with the estimate: 10%); at least 20-fold (1.30 log units) between middle value and limit.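

Among these compounds, on the sulfonyl sulfur, a place no earlier step touched, amino in place of methyl gives an at least 15-fold higher number from compound 2 to compound 3 (1.18 log units; beyond the scatter) in this assay. Among the compounds shown here, compound 3 has a limit and not a number, so this step has a lower bound only: the limit of > 50000 nM in this assay, at which 1 of the 3 values shown sits. Compound 2 thus remains the only one of the three compounds with a number, and the methyl on the aromatic carbon, present in both compound 2 and compound 3, does not secure one. The compounds shown leave open how an ethyl or a dimethylamino group on the sulfonyl sulfur would read in this assay.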